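A few compounds are considered here, and "the series" means these few. Any claim that something is new, unique, unknown or untested is made for them only; others in the source may bear on it.

In an in vitro ADME assay on microsomes from liver (Homo sapiens) for metabolic stability (on this read-out higher numbers stand for fast clearance and lower numbers for slow clearance), compound 1 (`O=C(COCc1ccccc1)N1CCN(c2ccc(F)cc2)CC1`) gives 110 mL.min-1.g-1 and compound 2 (`Cc1cc(Cl)ccc1N1CCN(C(=O)COCc2ccncc2)CC1`) gives 68 mL.min-1.g-1. At the low end stands compound 3 (`O=C(COCc1cnccn1)N1CCN(c2ccc(Cl)cc2Cl)CC1`) with 4 mL.min-1.g-1, the lowest of the three numbers and beyond the scatter from both others. Compound 4 (`O=C(COCc1nccs1)N1CCN(c2ccc(Cl)cc2Cl)CC1`) differs from compound 3 in one place: 1,3-thiazol-2-yl in place of pyrazin-2-yl on a saturated chain carbon bound to an oxygen on a saturated carbon. Among the measured compounds shown here, no measured pair shows this change or any other single change, so the expectation is loose. Because compound 3 sits at 4 mL.min-1.g-1 a rise is thought likelier than a fall, modest and only slightly beyond the scatter. The expected step is a 2.8-fold higher number from compound 3 to compound 4 (0.44 log units; beyond the scatter). For compound 4 the estimated value is 11 mL.min-1.g-1, with an expected range from 4 mL.min-1.g-1 to 35 mL.min-1.g-1.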

Compound 4, intrinsic clearance in microsomes: 80 mL.min-1.g-1
The estimate for compound 4 lay 7.3-fold (0.86 log units) below the measured number; measured number above the stated range.
By their numbers in this assay, from the lowest: compound 3; then compounds 2, 4 and 1 (each within the scatter of the next).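

In this assay the exchange of pyrazin-2-yl for 1,3-thiazol-2-yl on a saturated chain carbon bound to an oxygen on a saturated carbon gives a 20-fold higher number from compound 3 to compound 4 (1.30 log units; beyond the scatter) with the rest of the molecule unchanged. Among the compounds shown here, this large step shows that the read-out is sensitive to the aromatic ring at this position, which no earlier pair could show. Nothing shown here explains the size of this step.

On these data alone, whether the exchange gives a similar step on a differently substituted core remains open. So does how an amine or a carboxylic acid would read in this place.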